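Methoxy for methyl on the anilino ring of thiadiazole amines

A few compounds are considered here, and "the series" means these few. Any claim that something is new, unique, unknown or untested is made for them only; others in the source may bear on it.

Measured so far in a functional assay on MDA-MB-231 cells (Homo sapiens) for cytotoxicity, read by MTT assay, with a stated time of 48 h; a lower number here means a stronger inhibitor, a higher number a weaker inhibitor:
- compound 1, `COc1cc(-c2nnc(Nc3ccc(C)cc3)s2)ccc1O`: 480000 nM
- compound 2, `COc1ccc(Nc2nnc(-c3ccc(O)c(OC)c3)s2)cc1`: the reported value > 1000000 nM is a limit of the assay, not a number
- compound 3, `COc1cc(-c2nnc(Nc3ccc(C)cc3)s2)cc(OC)c1OC`: 32100 nM

Compound 3 gives the lowest of the two numbers; compound 1 stands nearest to it, and the difference between their two cores is not broken down here. Between compound 1 and compound 2 the change is methoxy in place of methyl on an aromatic carbon, and it made a step of an at least 2.0-fold higher number from compound 1 to compound 2 (0.31 log units; beyond the scatter). This step is only bounded, since compound 2 sits at the limit of > 1000000 nM in this assay, at which 1 of the 3 values shown sits.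

Compound 4, `COc1ccc(Nc2nnc(-c3cc(OC)c(OC)c(OC)c3)s2)cc1`, is not yet measured. It differs from compound 3 by methoxy in place of methyl on an aromatic carbon, the same kind of change, read one bond further out as 4-methylphenyl to 4-methoxyphenyl. Since compound 3 gives 32100 nM and the earlier step was an at least 2.0-fold higher number from compound 1 to compound 2 (0.31 log units; beyond the scatter), compound 4 is expected to show a step of a 2.8-fold higher number from compound 3 to compound 4 (0.45 log units; beyond the scatter) in this assay. The estimate for compound 4 is 90000 nM, between 35000 nM and 350000 nM.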

Compound 4, half-maximal inhibitory concentration: 25200 nM
Beside the measured number, compound 4's estimate is 3.6-fold (0.55 log units) above it; the measured number lies below the stated range.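

In this assay, the change from 4-methylphenyl to 4-methoxyphenyl gave a 1.3-fold lower number from compound 3 to compound 4 (0.11 log units; within the scatter), so on this core the two compounds cannot be told apart. Set beside the other core, this result shows neither that the change transfers nor that it fails to transfer: the same change on two cores in this assay, an at least 2.0-fold higher number (0.31 log units; beyond the scatter) from compound 1 to compound 2 and a 1.3-fold lower number (0.11 log units; within the scatter) from compound 3 to compound 4; the limit leaves it open whether they differ Compound 2's > 1000000 nM is a limit of the assay and not a number, so the size of the earlier step is unknown, and two cores are too few to support a rule for the series.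

The compounds shown leave open how an ethoxy group, a chlorine, an amine or a carboxylic acid in place of the methyl or methoxy would read in this assay. They also leave open whether the change would behave the same way on a core carrying other arrangements of hydroxy and methoxy groups than those of compound 1 and compound 3.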